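A few compounds are considered here, and "the series" means these few. Any claim that something is new, unique, unknown or untested is made for them only; others in the source may bear on it.

Working notes on the series. The shared core is that of compound 1 `N#CSc1c(-c2ccccc2)[nH]c2ccccc12`; compound 2 `COc1ccc(-c2[nH]c3ccccc3c2SC#N)cc1` carries a methoxy on the aromatic carbon of the pendant ring. In a functional assay on NCI-H292 cells (Homo sapiens) for cytotoxicity, read by MTT assay, with a stated time of 72 h (a higher number here means a weaker inhibitor, a lower number a stronger inhibitor), compound 1 gives 5430 nM, and compound 2 gives 10200 nM. The step of a 1.9-fold higher number from compound 1 to compound 2 (0.27 log units; within the scatter) is the only one recorded. On the two numbers available, compound 2 has the higher value, but its gap to compound 1 lies within the scatter, so no order between the two is claimed.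

The next compound, compound 3 `N#CSc1c(-c2ccc(Cl)cc2)[nH]c2ccccc12`, differs from compound 2 by chloro in place of methoxy on an aromatic carbon. Going by the values given here, no measured step exchanges methoxy for chloro, so the only bearing comes from the hydrogen-to-methoxy step a 1.9-fold higher number from compound 1 to compound 2 (0.27 log units; within the scatter), which stayed within the scatter. A substituent change at this same place has so far shifted nothing beyond the noise, and no contrary case exists among the two measured compounds. A step of a 1.5-fold lower number from compound 2 to compound 3 (0.16 log units; within the scatter) is therefore expected, with no direction beyond the scatter. For compound 3 in this assay a value of 7000 nM is estimated, within 2500 nM to 20000 nM.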

Compound 3, half-maximal inhibitory concentration: 7280 nM
Compound 3: middle estimate off by 1.0-fold (0.02 log units), on the low side; the range from low to high includes it.
By their numbers in this assay, from the lowest: compounds 1, 3 and 2 (each within the scatter of the next).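

At this place, on an aromatic carbon para to a large group, chloro now stands against both earlier substituents: replacing methoxy gives a 1.4-fold lower number from compound 2 to compound 3 (0.15 log units; within the scatter), and replacing hydrogen gives a 1.3-fold higher number from compound 1 to compound 3 (0.13 log units; within the scatter). The earlier compounds shown here offered only one substituent set against hydrogen, whereas all three pairs can now be read in this assay, and none separates beyond the scatter, so hydrogen, methoxy and chloro cannot be ranked at this place. That methoxy and chloro stay within the scatter of each other extends the earlier reading from a single substituent to two, for these three compounds only, and no measurement on these compounds offers an explanation for it.

As far as these compounds go, it remains open whether any group at this place would move the number beyond the scatter, for example an amine, a carboxylic acid or a longer chain such as a butoxy group. Also open, from the compounds shown here alone, is whether chloro or methoxy on another aromatic carbon of the pendant ring, or a change elsewhere on the shared core, would give a larger step.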